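This account rests on a few compounds, and the source may have more. Where it says the series, first, only, none or still open, it means among the compounds named here.

Compound 1 `O=C(c1cccc(Nc2ncc(F)c(Nc3ccc(F)cc3)n2)c1)N1CCCCC1`: 13200 nM
Compound 2 `CN(C)CC(=O)Nc1cccc(Nc2ncc(F)c(Nc3ccc(F)cc3)n2)c1`: 1180 nM
Compound 3 `O=C(Nc1cc(Cl)cc(Cl)c1)c1cccc(Nc2ncc(F)c(Nc3ccc(F)cc3)n2)c1`: 17500 nM

In a functional assay on A549 cells (Homo sapiens) for antiproliferative activity, read by sulforhodamine B assay, with a stated time of 3 days (a lower number here means a stronger inhibitor of growth, a higher number a weaker inhibitor of growth), compound 3 gives the highest of the three numbers. The step of a 1.3-fold higher number from compound 1 to compound 3 (0.12 log units; within the scatter) lies within the scatter, so compounds 1 and 3 cannot be ordered, whereas a 15-fold higher number from compound 2 to compound 3 (1.17 log units; beyond the scatter) is a large step beyond it.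

Compound 4 `O=C(Nc1cccc(Nc2ncc(F)c(Nc3ccc(F)cc3)n2)c1)c1ccccc1` has not yet been measured. Its change from compound 3 is benzamido in place of (3,5-dichlorophenyl)carbamoyl on an aromatic carbon. The closest guide is compound 2, which also carries an amino-type group, (((dimethylamino)methyl)carbonyl)amino, on the same aromatic carbon and gave an 11-fold lower number from compound 1 to compound 2 (1.05 log units; beyond the scatter); the reverse, a 15-fold higher number from compound 2 to compound 3 (1.17 log units; beyond the scatter), was also large. A lower number is therefore expected for compound 4, estimated at a 3.5-fold lower number from compound 3 to compound 4 (0.54 log units; beyond the scatter), though less than the full swing of compound 2. Compound 4 is expected at 5000 nM, between 1500 nM and 16000 nM.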

Compound 4, concentration for 50% growth inhibition: 37800 nM
Compound 4: middle estimate off by 7.6-fold (0.88 log units), on the low side; measured number outside the range, above it.
By their numbers in this assay, from the lowest: compound 2; then compounds 1 and 3 (each within the scatter of the next); then compound 4.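

The amino link on this aromatic carbon does not by itself give a low number in this assay, since benzamido in place of (3,5-dichlorophenyl)carbamoyl gives (a 2.2-fold higher number from compound 3 to compound 4 (0.33 log units; beyond the scatter)) and benzamido in place of (piperidin-1-yl)carbonyl gives (a 2.9-fold higher number from compound 1 to compound 4 (0.46 log units; beyond the scatter)). With that link kept, phenyl in place of (dimethylamino)methyl on the carbonyl carbon gives (a 32-fold higher number from compound 2 to compound 4 (1.51 log units; beyond the scatter)), so the low number of compound 2 is tied to the group on that carbonyl. No measurement here explains these steps. Still open, as far as these compounds go, is whether another amine on that carbonyl, such as a morpholine or a longer aminoalkyl chain, would hold the low number, or whether a carboxylic acid there would lose it.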